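From acetyl(methyl)amino to 4-hydroxy-2-oxopiperidin-1-yl

A few compounds are considered here, and "the series" means these few. Any claim that something is new, unique, unknown or untested is made for them only; others in the source may bear on it.

Compounds measured so far in an ADME assay on microsomes from liver (Homo sapiens) for metabolic stability, read by LC-MS, using NADPH, with a stated time of 30 min, tested at 1 uM (on this read-out lower numbers stand for slow clearance and higher numbers for fast clearance), are these
compound 1 `CC(C)c1noc(N2CCC(Oc3cc(N4CCc5cc(C6CCCCC6=O)ccc54)ncn3)CC2)n1` gives 78 mL.min-1.g-1
compound 2 `CCc1cnc(N2CCC(C(C)COC(=O)N3CCc4cc(S(C)(=O)=O)cc(F)c43)CC2)nc1` gives 329 mL.min-1.g-1
compound 3 `CC(=O)N(C)c1ccc2c(c1)CCN2c1cc(OC2CCN(c3nc(C(C)C)no3)CC2)ncn1` gives 173 mL.min-1.g-1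

Compound 3 lies within the usual scatter of compound 2, and beyond the scatter from compound 1. The next structure, compound 4 `CC(C)c1noc(N2CCC(Oc3cc(N4CCc5cc(N6CCC(O)CC6=O)ccc54)ncn3)CC2)n1`, carries 4-hydroxy-2-oxopiperidin-1-yl in place of acetyl(methyl)amino on an aromatic carbon and so again has a six-membered non-aromatic ring at that carbon.

Compound 2 differs too widely to bear on this change. Among the measured compounds shown here, the one measured step at this carbon is a 2.2-fold higher number from compound 1 to compound 3 (0.35 log units; beyond the scatter) with acetyl(methyl)amino in place of 2-oxocyclohexyl, a modest step. Compound 1 at 78 mL.min-1.g-1 is therefore the nearest guide, since its 2-oxocyclohexyl group is also a six-membered non-aromatic ring with a carbonyl. For the measured compounds named here, no measured compound carries 4-hydroxy-2-oxopiperidin-1-yl, so this comparison is loose and the range stays wide.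

A modest step toward lower numbers is expected, estimated as a 2.2-fold lower number from compound 3 to compound 4 (0.33 log units; beyond the scatter) and similar in size to the measured one. For compound 4 the estimated value is 80 mL.min-1.g-1 with an expected range from 35 mL.min-1.g-1 to 170 mL.min-1.g-1 in this assay until the measurement arrives.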

Compound 4, intrinsic clearance in microsomes: 4 mL.min-1.g-1
Compound 4: the middle estimate sits 20-fold (1.30 log units) above what was measured, outside the stated range (below it).
By their numbers in this assay, from the lowest: compound 4; then compound 1; then compounds 3 and 2 (each within the scatter of the next).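

In this assay, among the compounds shown here, replacing acetyl(methyl)amino with 4-hydroxy-2-oxopiperidin-1-yl on this aromatic carbon gives a far larger change (a 43-fold lower number from compound 3 to compound 4 (1.64 log units; beyond the scatter)) than the only earlier step at the same carbon (a 2.2-fold higher number from compound 1 to compound 3 (0.35 log units; beyond the scatter)), so this place can shift the read-out much further than the first pair suggested. A six-membered non-aromatic ring bearing a carbonyl is not enough on its own to give the low number, since moving from 2-oxocyclohexyl to 4-hydroxy-2-oxopiperidin-1-yl is also a large step (a 20-fold lower number from compound 1 to compound 4 (1.29 log units; beyond the scatter)). Nothing available here accounts for the size of either new step.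

As far as these compounds go, whether the step goes with the hydroxy, with the ring nitrogen or with both stays open, and a plain 2-oxopiperidin-1-yl or a 4-methoxy-2-oxopiperidin-1-yl group at this carbon would be needed to separate them. Also open, from the compounds shown here alone, is what an open-chain amine or a carboxylic acid would give at this carbon, and whether the low number would hold if the isopropyl on the far ring of the core of compound 4 were replaced by another group.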